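The source may hold more compounds than are shown below. What is called first, only, known or untested is meant among the compounds shown, and "the series" means these compounds.

Working notes. Compound 1 `c1ccc(CCCN2CCC(CCOC(c3ccccc3)c3ccccc3)CC2)cc1` gives 12 nM in an assay on striatum for binding affinity to sodium-dependent dopamine transporter (Rattus norvegicus) (a higher number here means a weaker inhibitor, a lower number a stronger inhibitor), the lowest of the three numbers in hand. Compound 2 `Brc1ccc(C(OCCC2CCN(CCCc3ccccc3)CC2)c2ccc(Br)cc2)cc1` gives 159 nM and compound 3 `COc1ccc(C(OCCC2CCN(CCCc3ccccc3)CC2)c2ccc(OC)cc2)cc1` gives 255 nM; both sit higher than compound 1, and both gaps are beyond the scatter. Compound 4 `c1ccc(CN2CCC(CCOC(c3ccccc3)c3ccccc3)CC2)cc1` has not yet been measured. It differs from compound 1 in one place: phenyl in place of phenethyl on a saturated chain carbon bound to an amine nitrogen in a ring. Going by the values given here, no measured pair here isolates this shortening of the chain on the ring nitrogen, so the step rests on judgement alone. The expectation is that compound 4 will be weaker than compound 1 by a step of an 8.3-fold higher number from compound 1 to compound 4 (0.92 log units; beyond the scatter), a loss clearly beyond the scatter. Compound 4 is therefore estimated at 100 nM, with a range from 30 nM to 400 nM.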

Compound 4, half-maximal inhibitory concentration: 15.2 nM
Beside the measured number, compound 4's estimate is 6.6-fold (0.82 log units) above it; the measured number lies below the stated range.
By their numbers in this assay, from the lowest: compounds 1 and 4 (each within the scatter of the next); then compounds 2 and 3 (each within the scatter of the next).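

Going by these compounds alone, the change from 3-phenylpropyl to benzyl gives a 1.3-fold higher number from compound 1 to compound 4 (0.10 log units; within the scatter) in this assay and is the first single-place comparison at this position. On this pair, the two chain lengths on the ring nitrogen cannot be told apart, so this shortening costs no measurable affinity. No available evidence bears on this result.

Still open, as far as these compounds go, is whether a longer chain, such as 5-phenylpentyl, or a ring nitrogen carrying only a methyl group, would stay level with these two compounds.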